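The source may report more compounds than this note shows. Statements on the series, on what has been measured and on what is new or still open speak of the compounds shown alone.

Measured in a functional assay on PC-3 cells (Homo sapiens); on this read-out higher numbers stand for weaker inhibition of growth and lower numbers for stronger inhibition of growth:
compound 1 `O=S(=O)(/C=C/c1ccc(Cl)c(Cl)c1)Cc1ccc(Nc2ncnc3ccccc23)cc1` gives 35000 nM
compound 2 `O=S(=O)(/C=C/c1ccc(Cl)cc1)Cc1ccc(Nc2ncnc3ccccc23)cc1` gives 43000 nM
compound 3 `O=S(=O)(/C=C/c1ccc(Cl)c(Cl)c1)Cc1ccc(Nc2ncnc3ccc(Br)cc23)cc1` gives 11000 nM

Compound 3 has the lowest number of the three, at 11000 nM. The next step leads to compound 4 `O=S(=O)(/C=C/c1ccc(Cl)cc1)Cc1ccc(Nc2ncnc3ccc(Br)cc23)cc1` and is described by hydrogen in place of chloro on an aromatic carbon. This puts hydrogen in place of chloro on an aromatic carbon, turning 3,4-dichlorophenyl into 4-chlorophenyl.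

The same change has been measured once, without the bromo group, as a 1.2-fold higher number from compound 1 to compound 2 (0.09 log units; within the scatter). That step lies within the scatter. The other measured step, a 3.2-fold lower number from compound 1 to compound 3 (0.50 log units; beyond the scatter), is modest but beyond the scatter. It adds bromo in place of hydrogen, and that bromo group is present in both compound 3 and compound 4, so it shows the background of the new step and not the size of the step itself. Whether the chloro change behaves alike with bromo present has not been tested, and the precedent is a single pair.

No step beyond the scatter is therefore expected in this assay, with at most a slight drift toward a higher number. The expected step is a 1.2-fold higher number from compound 3 to compound 4 (0.07 log units; within the scatter). For compound 4 the estimated value is 13000 nM, with an expected range from 7000 nM to 24000 nM.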

Compound 4, concentration for 50% growth inhibition: 2000 nM
For compound 4 the middle estimate is 6.5-fold (0.81 log units) above the measured one, outside the stated range (below it).
By their numbers in this assay, from the lowest: compound 4; then compound 3; then compounds 1 and 2 (each within the scatter of the next).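

In this assay, the change from 3,4-dichlorophenyl to 4-chlorophenyl does not carry over from one core to the other: it lies within the scatter without the bromo group, but with the bromo group present it gives a 5.5-fold lower number from compound 3 to compound 4 (0.74 log units; beyond the scatter), so its effect depends on the group elsewhere in the molecule: the same change on two cores in this assay, a 1.2-fold higher number (0.09 log units; within the scatter) from compound 1 to compound 2 and a 5.5-fold lower number (0.74 log units; beyond the scatter) from compound 3 to compound 4, 6.8-fold (0.83 log units) apart, beyond the scatter of two such steps Seen from the other side, the bromo step also depends on the aryl group, and on the 4-chlorophenyl compounds it reaches a 22-fold lower number from compound 2 to compound 4 (1.33 log units; beyond the scatter), well beyond its size on the 3,4-dichlorophenyl compounds: the same change on two cores in this assay, a 3.2-fold lower number (0.50 log units; beyond the scatter) from compound 1 to compound 3 and a 22-fold lower number (1.33 log units; beyond the scatter) from compound 2 to compound 4, 6.8-fold (0.83 log units) apart, beyond the scatter of two such steps The two substitutions are therefore not additive across these four compounds, and the chloro group at this position cannot be judged apart from the bromo group.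

Going by these compounds, it remains open whether this dependence extends to other groups, such as a methoxy or a fluoro group in place of the chloro, or an amine in place of the bromo. Also open, on these data alone, is whether the same interplay appears in any read-out other than this assay, as the whole pattern rests on a single set of four compounds.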